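A few compounds are considered here, and "the series" means these few. Any claim that something is new, unique, unknown or untested is made for them only; others in the source may bear on it.

Of the compounds shown here, three sharing one core have been measured in a functional assay on KB cells (Homo sapiens) for antiproliferative activity, read by sulforhodamine B assay, with a stated time of 3 days; a lower number here means that less compound is needed, a higher number that more compound is needed for the effect. Compound 1 `CCC1=C(O)c2c(oc(-c3ccc(F)cc3)cc2=O)C(CC)(CC)C1=O` gives 33 uM in this assay. Compound 2 `CCC1=C(O)c2c(oc(-c3ccc(COC)cc3)cc2=O)C(CC)(CC)C1=O` reaches only the limit of this assay, > 52.4 uM, so for it no number is known. Compound 3 `CCC1=C(O)c2c(oc(-c3ccc(C)cc3C)cc2=O)C(CC)(CC)C1=O` gives 41.2 uM in this assay. Compound 3 thus sits close to compound 1, with a 1.2-fold higher number from compound 1 to compound 3 (0.10 log units; within the scatter), and against compound 2 there is only an at least 1.2-fold lower number from compound 2 to compound 3 (0.10 log units; that floor lies within the scatter), a floor set by the limit of > 52.4 uM in this assay, at which 1 of the 3 values shown sits, rather than a true number.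

Compound 4 `CCC1=C(O)c2c(oc(-c3cc(C)ccc3C)cc2=O)C(CC)(CC)C1=O` has not yet been measured. It differs from compound 3 only in the aryl group on the core, described as 2,5-dimethylphenyl in place of 2,4-dimethylphenyl on an aromatic carbon.

Within the data shown here, no measured step swaps one dimethylphenyl pattern for another, so the measured steps bear on this change only loosely. The two that replace the aryl group, a 1.2-fold higher number from compound 1 to compound 3 (0.10 log units; within the scatter) and an at least 1.2-fold lower number from compound 2 to compound 3 (0.10 log units; that floor lies within the scatter), are both small or undetermined. Moving one methyl group from one ring position to another is a smaller alteration than either of those, so no step beyond the scatter is expected in this assay for compound 4.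

Compound 4 is therefore expected to show a 1.0-fold higher number from compound 3 to compound 4 (0.01 log units; within the scatter), landing at an estimated 42 uM, with a likely range from 20 uM to 90 uM.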

Compound 4, concentration for half-maximal effect: 14.5 uM
The estimate for compound 4 lay 2.9-fold (0.46 log units) above the measured number; the whole stated range lies above it.
By their numbers in this assay, from the lowest: compound 4; then compounds 1 and 3 (each within the scatter of the next). At a limit, above all of these: compound 2.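

In this assay, moving a single methyl group within the aryl group, on the aromatic carbon next to the ring oxygen, gives a 2.8-fold lower number from compound 3 to compound 4 (0.45 log units; beyond the scatter), although the atoms stay the same and the donor and acceptor counts remain zero on both sides. The earlier aryl swaps had shown no step beyond the scatter, so this is the first sign that the placement of a methyl group on this aryl ring can shift the number, and compound 4 also separates from the fluorinated compound, with a 2.3-fold lower number from compound 1 to compound 4 (0.36 log units; beyond the scatter). The third new step, an at least 3.6-fold lower number from compound 2 to compound 4 (0.55 log units; beyond the scatter), is only a floor, resting on a limit and not on a true number: the limit of > 52.4 uM in this assay, at which 1 of the 4 values shown sits.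

These compounds do not show what lies behind the difference between the 2,4-dimethylphenyl and 2,5-dimethylphenyl groups, nor whether it depends on one methyl group or on the pair. Going by these compounds, it also remains open whether a 2,5-dichlorophenyl group, or an aryl group carrying an amine or a carboxylic acid, would keep or lose the lower number seen for compound 4.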